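A few compounds are considered here, and "the series" means these few. Any claim that something is new, unique, unknown or untested is made for them only; others in the source may bear on it.

Measured compounds in a functional assay on SW480 cells (Homo sapiens) for inhibition, read by luminescence and resazurin assay, with a stated time of 3 days; a lower number here means a stronger inhibitor, a higher number a weaker inhibitor:
compound 1 `CCCNc1nc(NCc2ccc(C(=O)NCc3ccc(F)cc3)cc2)c2cc(C)ccc2n1`: 2200 nM
compound 2 `CCCNc1nc(NCc2ccc(C(=O)Nc3ccc(F)cc3)cc2)c2ccccc2n1`: 1600 nM
compound 3 `CCCNc1nc(NCc2ccc(C(=O)Nc3ccc(Cl)nc3)cc2)c2cc(C)ccc2n1`: 2100 nM

The three numbers sit close together. Compound 1 gives the highest of them, yet the step of a 1.0-fold lower number from compound 1 to compound 3 (0.02 log units; within the scatter) is within the scatter, and the gap between compound 1 and compound 2 is also within the scatter, so no ordering among the three is secure. Compound 4 `Cc1ccc2nc(N3CCNC(C)C3)nc(NCc3ccc(C(=O)NCc4ccc(F)cc4)cc3)c2c1` differs from compound 1 by 3-methylpiperazin-1-yl in place of propylamino on an aromatic carbon. Among the compounds with values here, the one measured step, a 1.0-fold lower number from compound 1 to compound 3 (0.02 log units; within the scatter), concerns a change on the amide-type nitrogen and was within the scatter; no measured pair touches the aromatic carbon where the 3-methylpiperazin-1-yl group enters. Within the data shown here, the numbers therefore give no basis for predicting a shift in this assay in either direction, and the narrow spread among compound 1, compound 2 and compound 3 is the only guide. Compound 4 is expected to land near compound 1, an estimated step of no change at the digits printed from compound 1 to compound 4 (within the scatter), with a wide range around it. The estimate for compound 4 in this assay is 2200 nM, between 700 nM and 7000 nM.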

Compound 4, half-maximal inhibitory concentration: 1400 nM
Compound 4: the middle estimate sits 1.6-fold (0.20 log units) above what was measured; low and high end bracket the measured number.
By their numbers in this assay, from the lowest: compounds 4, 2, 3 and 1 (each within the scatter of the next).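

Within the data shown here, all the earlier compounds carry propylamino on the aromatic carbon between two ring nitrogen atoms, so compound 4 is the first to show a different group there in this assay. The step, a 1.6-fold lower number from compound 1 to compound 4 (0.20 log units; within the scatter), shows that replacing this open chain with 3-methylpiperazin-1-yl, which brings a six-membered non-aromatic ring, leaves the number within the scatter, so this position accepts the ring without a readable shift. Nothing available here accounts for this result.

As far as these compounds go, it remains open whether a morpholine ring, a carboxylic acid or a longer alkyl amine at this position would move the number beyond the scatter. From the compounds shown here alone, it is also open whether 3-methylpiperazin-1-yl would give the same result alongside the amide groups of compound 2 and compound 3.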